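Carboxyphenyl in place of trifluoromethylphenyl on a shared core

This account rests on a few compounds, and the source may have more. Where it says the series, first, only, none or still open, it means among the compounds named here.

Measured compounds:
compound 1 `O=C1c2ccc(OCc3cccc(-c4ccc(C(F)(F)F)cc4F)c3)cc2CN1C1CCCC1`, in an assay on HEK293 cells for positive allosteric modulation of metabotropic glutamate receptor 2 (Rattus norvegicus), read by thallium flux (on this read-out higher numbers stand for larger maximal responses and lower numbers for smaller maximal responses), reported as "not determined" (no result reported);
compound 2 `O=C(O)c1cc(-c2cccc(COc3ccc4c(=O)n(C5CCCC5)sc4c3)c2)cc([N+](=O)[O-])c1`, 86.1%.

Compound 1 has no single number in this assay, so its standing cannot be placed. Compound 2 gives 86.1%. Compound 3 `O=C(O)c1ccc(-c2cccc(COc3ccc4c(c3)CN(C3CCCC3)C4=O)c2)c(Cl)c1` arises from compound 1 by 4-carboxy-2-chlorophenyl in place of 2-fluoro-4-(trifluoromethyl)phenyl on an aromatic carbon. For the measured compounds named here, with no measured step between these two, the size of the step in this assay is unknown, and compound 2 alone suggests a large maximal response may be reached. For compound 3 the maximal response is expected to be about 80%, between 55% and 105%.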

Compound 3, largest response reached (reported as percent of maximum), in percent of the reference or control that the assay uses: 89.4%
For compound 3 the middle estimate is 9.4 percentage points below the measured one; the measured number falls inside the stated range.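

In this assay, for the compounds shown here, compound 1 has no single number, so no step to compound 3 can be read. Going by these compounds, what the exchange of 2-fluoro-4-(trifluoromethyl)phenyl for 4-carboxy-2-chlorophenyl does to the maximal response stays open, and no evidence bears on it.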